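Swapping Benzyl for 4-Methylphenyl on the Amide Nitrogen

The compounds below may be only part of what the source reports. "The series", "measured", "known", "first", "only" and "open" are said of these compounds alone.

For the measured compounds named here, compound 1 `COc1ccc2c(=O)c(/C=C/C(=O)NCc3ccccc3)coc2c1` gives 11800 nM in a functional assay on A549 cells (Homo sapiens) for inhibition, read by MTT assay, with a stated time of 48 h (a higher number here means a weaker inhibitor, a lower number a stronger inhibitor), one of only two numbers so far, the other sitting within the scatter of it. Compound 2 `COc1cccc(NC(=O)/C=C/c2coc3cc(OC)ccc3c2=O)c1` gives 12800 nM in this assay, and a 1.1-fold higher number from compound 1 to compound 2 (0.04 log units; within the scatter) describes that small step. Compound 3 `COc1ccc2c(=O)c(/C=C/C(=O)Nc3ccc(C)cc3)coc2c1` differs from compound 1 by 4-methylphenyl in place of benzyl on an amide-type nitrogen. Going by the values given here, the one step that bears on this, a 1.1-fold higher number from compound 1 to compound 2 (0.04 log units; within the scatter), also replaced benzyl on an amide-type nitrogen, there with 3-methoxyphenyl, and stayed within the scatter, so no step beyond the scatter is expected here. Compound 3 is therefore estimated at 12000 nM, with a range from 6000 nM to 24000 nM, meaning a 1.0-fold higher number from compound 1 to compound 3 (0.01 log units; within the scatter) as the expected step.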

Compound 3, half-maximal inhibitory concentration: 17500 nM
Compound 3: the middle estimate sits 1.5-fold (0.16 log units) below what was measured, within the range that was stated.
By their numbers in this assay, from the lowest: compounds 1, 2 and 3 (each within the scatter of the next).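

On this amide-type nitrogen, 4-methylphenyl gives a 1.5-fold higher number from compound 1 to compound 3 (0.17 log units; within the scatter) and a 1.4-fold higher number from compound 2 to compound 3 (0.14 log units; within the scatter) in this assay. A second aromatic replacement for benzyl has therefore stayed within the scatter, and the three groups on this nitrogen cannot yet be ranked. No separate measurement bears on why these numbers stay so close.

As far as these compounds go, whether any group at this position can move the number beyond the scatter remains open. A longer chain between the nitrogen and the ring, or a phenyl ring carrying an amine or a carboxylic acid, could test this.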